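Pyrrolidinylmethyl ether in place of the oxanylethyl ether

The compounds below may be only part of what the source reports. "The series", "measured", "known", "first", "only" and "open" are said of these compounds alone.

Within the data shown here, compound 2 `CC(Oc1ccc(S(=O)(=O)NC(=O)c2ccc(N3CCN(CC4=C(c5ccc(C(F)(F)F)cc5)CC(C)(C)CC4)CC3)cc2Oc2cnc3[nH]ccc3c2)cc1[N+](=O)[O-])C1CCOCC1` holds the higher of the two numbers measured so far in an assay on isolated protein for displacement of a labelled ligand from Apoptosis regulator Bcl-2 (Homo sapiens), with a stated time of 15 min; a lower number here means a stronger inhibitor, a higher number a weaker inhibitor: in this assay compound 2 gives 9.2 nM. Among the measured compounds shown here, its only measured neighbour is compound 1 `CN1CCC(CNc2ccc(S(=O)(=O)NC(=O)c3ccc(N4CCN(CC5=C(c6ccc(C(F)(F)F)cc6)CC(C)(C)CC5)CC4)cc3Oc3cnc4[nH]ccc4c3)cc2[N+](=O)[O-])C1`, which in this assay gives 2.4 nM. For the measured compounds named here, the single step between them, a 3.8-fold higher number from compound 1 to compound 2 (0.58 log units; beyond the scatter), is the only one recorded in this set, and it goes with the exchange of the amine-linked side chain of compound 1 for the ether-linked side chain of compound 2.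

Compound 3 `CN1CCC(COc2ccc(S(=O)(=O)NC(=O)c3ccc(N4CCN(CC5=C(c6ccc(C(F)(F)F)cc6)CC(C)(C)CC5)CC4)cc3Oc3cnc4[nH]ccc4c3)cc2[N+](=O)[O-])C1` has not yet been measured. It differs from compound 2 by (1-methylpyrrolidin-3-yl)methyl in place of 1-(oxan-4-yl)ethyl on an oxygen on an aromatic ring, so it carries the side chain of compound 1 on the oxygen link of compound 2. Going by the values given here, the one step that bears on this change is a 3.8-fold higher number from compound 1 to compound 2 (0.58 log units; beyond the scatter), a modest rise on going the other way. Compound 3 is therefore expected to undo most of that rise and to come in with a number near that of compound 1, the estimated step being a 2.6-fold lower number from compound 2 to compound 3 (0.42 log units; beyond the scatter). In this assay compound 3 is estimated at 3.5 nM, within a range of 1.5 nM to 9 nM.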

Compound 3, half-maximal inhibitory concentration: 0.75 nM
Estimate against measurement, compound 3: 4.7-fold (0.67 log units) above, and the stated range ends above it.
By their numbers in this assay, from the lowest: compound 3; then compound 1; then compound 2.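

With the oxygen link held fixed, (1-methylpyrrolidin-3-yl)methyl in place of 1-(oxan-4-yl)ethyl gives a 12-fold lower number from compound 2 to compound 3 (1.09 log units; beyond the scatter) in this assay, so the side chain on this oxygen matters a great deal on its own. With the side chain held fixed, the ether link in place of the amine link gives a 3.2-fold lower number from compound 1 to compound 3 (0.51 log units; beyond the scatter) in the same assay, which shows that the link also moves the number and that the oxygen link does not account for the higher number of compound 2, whereas the earlier step from compound 1 to compound 2 had changed link and side chain together. Nothing among the available data explains why either change has the effect it does.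

The three compounds do not show whether the 1-(oxan-4-yl)ethyl group would respond to the amine link as the (1-methylpyrrolidin-3-yl)methyl group does. They also leave open how the number would move on the oxygen link with a pyrrolidine lacking the methyl group on its nitrogen, or with a piperidine or morpholine in its place.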